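Removing the phenyl from the cyano-bearing salicylanilide

This account rests on a few compounds, and the source may have more. Where it says the series, first, only, none or still open, it means among the compounds named here.

Measured compounds:
compound 1, `O=C(Nc1ccc(C(F)(F)F)cc1)c1cc(Br)ccc1O`, 610 nM
compound 2, `O=C(Nc1ccc(C(F)(F)F)cc1)c1cc(Br)c(-c2ccccc2)cc1O`, 400 nM
compound 3, `N#Cc1ccc(NC(=O)c2cc(Br)c(-c3ccccc3)cc2O)cc1`, 850 nM

Of the compounds shown here, three have been measured in a functional assay on KG-1 cells (Homo sapiens) for cytotoxicity, read by luminescence and CellTiter-Glo, with a stated time of 3 days; on this read-out lower numbers stand for stronger inhibition and higher numbers for weaker inhibition. Compound 2 is the reference point; compound 1 differs from it by hydrogen in place of phenyl on an aromatic carbon, and this gave a 1.5-fold higher number from compound 2 to compound 1 (0.18 log units; within the scatter). Compound 3 differs from compound 2 in the other part of the molecule, by cyano in place of trifluoromethyl on an aromatic carbon, which gave a 2.1-fold higher number from compound 2 to compound 3 (0.33 log units; beyond the scatter). Compound 3 therefore stands at the highest of the three numbers, though its gap to compound 1 is within the scatter.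

Compound 4, `N#Cc1ccc(NC(=O)c2cc(Br)ccc2O)cc1`, has not yet been measured in this assay. It differs from compound 3 by hydrogen in place of phenyl on an aromatic carbon. Within the data shown here, this is the same change as the one from compound 2 to compound 1, made at the same place, but now on the core that carries the cyano group rather than the trifluoromethyl group. Among the measured compounds shown here, only one earlier instance of the change exists, and it was small. The expectation rests on that instance: compound 4 is expected to give a number close to compound 3, shifted by about a 1.5-fold higher number from compound 3 to compound 4 (0.18 log units; within the scatter), because a 1.5-fold higher number from compound 2 to compound 1 (0.18 log units; within the scatter) was the step seen for the same change on the trifluoromethyl core. Compound 4 is therefore estimated at 1300 nM, with a range from 600 nM to 2800 nM.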

Compound 4, half-maximal inhibitory concentration: 1290 nM
Compound 4: the middle estimate sits 1.0-fold (0.00 log units) above what was measured, and the stated range covers the measured number.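

In this assay the replacement of phenyl by hydrogen gives a 1.5-fold higher number from compound 3 to compound 4 (0.18 log units; within the scatter) and so repeats, on the cyano-bearing compounds, the step seen on the trifluoromethyl-bearing compounds: the same change on two cores in this assay, a 1.5-fold higher number (0.18 log units; within the scatter) from compound 2 to compound 1 and a 1.5-fold higher number (0.18 log units; within the scatter) from compound 3 to compound 4, 1.0-fold (0.00 log units) apart, within the scatter of two such steps. The replacement of trifluoromethyl by cyano, now read on the compounds that carry hydrogen in place of phenyl, gives a 2.1-fold higher number from compound 1 to compound 4 (0.33 log units; beyond the scatter) and likewise repeats its earlier step: the same change on two cores in this assay, a 2.1-fold higher number (0.33 log units; beyond the scatter) from compound 2 to compound 3 and a 2.1-fold higher number (0.33 log units; beyond the scatter) from compound 1 to compound 4, 1.0-fold (0.00 log units) apart, within the scatter of two such steps. Within these four compounds the two changes therefore carry over from one core to the other with no sign that either depends on the other, but this rests on a single pair of steps for each change, and the phenyl step stays within the scatter on both cores, so the agreement shows only that this step is small in both cases and does not show that either step would hold on any other core or in any other cell line.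

The compounds shown leave open whether the same steps would hold if a chloro group or a methoxy group stood in place of the bromo group, or if an amine stood in place of the hydroxy group. They also leave open what a carboxylic acid in place of the cyano group, or a longer alkyl chain or a pyridine ring in place of the phenyl, would do in this assay.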